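Methyl to Chloro on the Anilide Ring: Cytotoxicity Expectation

The source may hold more compounds than are shown below. What is called first, only, known or untested is meant among the compounds shown, and "the series" means these compounds.

Measured so far:
compound 1 `Cc1ccccc1NC(=O)CSc1nncnc1-c1cccc2ccccc12` gives 158000 nM
compound 2 `O=C(CSc1nncnc1-c1ccccc1Cl)Nc1ccccc1Br` gives 73000 nM

In an ADME assay on MT4 cells (Homo sapiens) for cytotoxicity, read by MTT assay (on this read-out lower numbers stand for higher toxicity in this test and higher numbers for lower toxicity in this test), compound 1 holds the highest of the two numbers; compound 2 sits at a lower number, and that gap lies beyond the usual scatter. Compound 3 `O=C(CSc1nncnc1-c1cccc2ccccc12)Nc1ccccc1Cl` is not yet measured. It differs from compound 1 in one place: chloro in place of methyl on an aromatic carbon, the change being chloro in place of methyl on an aromatic carbon. For the measured compounds named here, no measured pair tells what this exchange does here. The step of a 1.3-fold lower number from compound 1 to compound 3 (0.12 log units; within the scatter) is expected to stay within the scatter, with no clear direction. Compound 3 is therefore estimated at 120000 nM, within a range from 50000 nM to 250000 nM.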

Compound 3, half-maximal cytotoxic concentration: 63000 nM
The estimate for compound 3 lay 1.9-fold (0.28 log units) above the measured number; low and high end bracket the measured number.
By their numbers in this assay, from the lowest: compounds 3 and 2 (each within the scatter of the next); then compound 1.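

In this assay, going from 2-methylphenyl to 2-chlorophenyl gives a 2.5-fold lower number from compound 1 to compound 3 (0.40 log units; beyond the scatter), so this exchange of one heavy atom, with no change in hydrogen-bond donors, acceptors or net charge, can shift the read-out towards higher toxicity in this test. This single pair gives the exchange a first measured size here, but it cannot establish a trend. No measurement at hand accounts for the shift. From the compounds shown here alone, whether fluoro, methoxy or an amine in the same place would give a similar number remains open. So does whether the exchange behaves the same way on another core.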